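Methoxy Removal on the Pendant Phenyl of Compound 3

The source may report more compounds than this note shows. Statements on the series, on what has been measured and on what is new or still open speak of the compounds shown alone.

Among the measured compounds shown here, compound 3 `COc1ccc(-c2cc(C(=O)Nc3ccc(Oc4ccnc5[nH]ccc45)cc3)ncn2)cc1` is the only member of the series with a number: in a functional assay on PC-3 cells (Homo sapiens) for cytotoxicity, read by MTT assay, with a stated time of 72 h (a lower number here means a stronger inhibitor, a higher number a weaker inhibitor), compound 3 gives 9830 nM. For the measured compounds named here, compound 1 `O=C(Nc1ccc(Oc2ccnc3[nH]ccc23)cc1)c1nccc(-c2ccc(Cl)cc2)n1` gives "not active" (no number reported) in this assay, and compound 2 `O=C(Nc1ccc(Oc2ccnc3[nH]ccc23)cc1)c1nccc(-c2ccc(F)cc2)n1` gives "not active" (no number reported); neither of these is a number, so no step among the measured compounds can be counted. Compound 4 `O=C(Nc1ccc(Oc2ccnc3[nH]ccc23)cc1)c1cc(-c2ccccc2)ncn1` differs from compound 3 by hydrogen in place of methoxy on an aromatic carbon. Going by the values given here, no measured pair covers this change. Compound 3 sits only at 9830 nM, and compound 1 and compound 2 give no number at all. The step of a 2.5-fold higher number from compound 3 to compound 4 (0.41 log units; beyond the scatter) is therefore expected to go toward a weaker inhibitor, beyond the scatter. Compound 4 is expected to give 25000 nM, within 8000 nM to 80000 nM, with a real chance that only a limit is reported.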

Compound 4, half-maximal inhibitory concentration: 240 nM
The estimate for compound 4 lay 100-fold (2.02 log units) above the measured number, outside the stated range (below it).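

In this assay the change from 4-methoxyphenyl to phenyl gives a 41-fold lower number from compound 3 to compound 4 (1.61 log units; beyond the scatter), so this position on the pendant ring responds strongly, and hydrogen is clearly preferred over methoxy here. The earlier compounds shown here offered no step that could show this. No measurement shown accounts for the size of the step. Going by these compounds, whether any group at this carbon costs activity or methoxy alone does remains open, and a methyl group or an amine there would help separate the two. Compound 1 and compound 2 differ from compound 4 in more than one place, so they cannot settle it.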